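Replacing a Thioether with Benzoyl on the Benzyl Arm

The compounds below may be only part of what the source reports. "The series", "measured", "known", "first", "only" and "open" are said of these compounds alone.

Compound 1, `CCC(CC)Oc1cccc(CN[C@H]2CC(C(=O)O)=C[C@@H](OC(CC)CC)[C@@H]2NC(C)=O)c1`, in an ADME assay on cells (Fibroblast, Gallus gallus) for cytotoxicity, read by CCK-8 assay, with a stated time of 48 h (on this read-out lower numbers stand for higher toxicity in this test and higher numbers for lower toxicity in this test), gives > 200000 nM, which is a limit of the assay rather than a number.
Compound 2, `CCC(CC)O[C@@H]1C=C(C(=O)O)C[C@H](NCc2ccc(SC(C)CC)cc2)[C@H]1NC(C)=O`, in this assay gives > 200000 nM, again a limit.
Compound 3, `CCC(CC)O[C@@H]1C=C(C(=O)O)C[C@H](NCc2cccc(SC3CCCC3)c2)[C@H]1NC(C)=O`, in this assay gives > 200000 nM, also a limit.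

All three measured compounds share one core and differ only in the group on the benzyl ring. Compound 2 stands at the same limit as the other two; nothing separates it from them on the numbers shown. For the measured compounds named here, the only single-point comparison, a step that the two limits leave unreadable from compound 1 to compound 3, cannot be read because of the limit of > 200000 nM in this assay, at which 3 of the 3 values shown sit.

Compound 4, `CCC(CC)O[C@@H]1C=C(C(=O)O)C[C@H](NCc2ccc(C(=O)c3ccccc3)cc2)[C@H]1NC(C)=O`, is the next compound to be measured. It differs from compound 2 by benzoyl in place of (sec-butyl)sulfanyl on an aromatic carbon.

Going by the values given here, no measured step bears on this change, and every measured value so far is a limit. Among the compounds with values here, the only guide is that all three measured compounds sit at the limit, so the expectation for compound 4 is the same, with no step beyond the scatter expected; the step of a number no higher from compound 2 to compound 4 (the limit leaves the size open) is estimated to be essentially flat. Compound 4 is therefore expected to give about 200000 nM, in a range from 100000 nM to 400000 nM, most likely reported again as a limit.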

Compound 4, half-maximal cytotoxic concentration: > 200000 nM
Compound 4: a limit, no number (the forecaster's own chance of this, stated with the estimate: 85%); the middle value lies on the limit itself.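

The step from compound 2 to compound 4, benzoyl in place of (sec-butyl)sulfanyl, cannot be read, because neither compound gives a number: the limit of > 200000 nM in this assay, at which 4 of the 4 values shown sit.

The compounds shown leave open how far beyond that limit each lies in this assay, and whether any change on the benzyl ring alters the read-out.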